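The source may report more compounds than this note shows. Statements on the series, on what has been measured and on what is new or still open speak of the compounds shown alone.

Measured in a functional assay on PC-3 cells (Homo sapiens) for cytotoxicity, read by MTT assay, with a stated time of 72 h; on this read-out higher numbers stand for weaker inhibition and lower numbers for stronger inhibition:
- compound 1 `COc1ccc(COCNc2n[n+]([O-])c3ccccc3[n+]2[O-])cc1`: 52800 nM
- compound 2 `COCNc1n[n+]([O-])c2ccccc2[n+]1[O-]`: 4270 nM

Compound 2 stands lowest of the two measured compounds. Compound 3 `CCOCNc1n[n+]([O-])c2ccccc2[n+]1[O-]` departs from compound 2 by methyl in place of hydrogen on a saturated chain carbon bound to an oxygen on a saturated carbon. This is methyl in place of hydrogen on a saturated chain carbon bound to an oxygen on a saturated carbon, or methoxymethyl to ethoxymethyl.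

For the measured compounds named here, only one measured step bears on this, at the same place: a 12-fold lower number from compound 1 to compound 2 (1.09 log units; beyond the scatter), with hydrogen in place of 4-methoxyphenyl. That single step shows a large rise in number with the larger group on compound 1 at 52800 nM. A methyl is a far smaller addition, so only a small move toward a higher number is expected in this assay, possibly none beyond the scatter. The expected step is a 1.2-fold higher number from compound 2 to compound 3 (0.07 log units; within the scatter). For compound 3 the estimate is 5000 nM, with an expected range of 2500 nM to 12000 nM.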

Compound 3, half-maximal inhibitory concentration: 7400 nM
Compound 3: the middle estimate sits 1.5-fold (0.17 log units) below what was measured; measured number inside the range.
By their numbers in this assay, from the lowest: compounds 2 and 3 (each within the scatter of the next); then compound 1.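

In this assay the change from methoxymethyl to ethoxymethyl gives a 1.7-fold higher number from compound 2 to compound 3 (0.24 log units; within the scatter) and so leaves hydrogen and methyl at this saturated chain carbon indistinguishable on the shared core. Compound 1 still stands apart, with a 7.1-fold lower number from compound 1 to compound 3 (0.85 log units; beyond the scatter) as a second step beyond the scatter, which places 4-methoxyphenyl alone among the three groups here. No measurement at hand accounts for either step.

From the compounds shown here alone, whether a longer chain such as propyl would stay with compound 2 and compound 3 or move toward compound 1 remains open. Going by these compounds, it is also open whether a plain phenyl, or an amine or a carboxylic acid at the end of the chain, would match 4-methoxyphenyl or fall with the smaller groups.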